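This account rests on a few compounds, and the source may have more. Where it says the series, first, only, none or still open, it means among the compounds named here.

Of the compounds shown here, three sharing one core have been measured in a physicochemical assay for lipophilicity, using the shake flask method, measured as octanol-water partition, at pH 7.4; on this read-out lower numbers stand for lower lipophilicity and higher numbers for higher lipophilicity. Compound 1 `COc1cc(/C=C/C(=O)Nc2ccccc2)ccc1OCCCN1CCCC1` gives 1.57, compound 2 `COc1cc(/C=C/C(=O)Nc2ccccc2)ccc1OCCCCN1CCCCC1` gives 1.61, and compound 3 `COc1cc(/C=C/C(=O)Nc2ccccc2)ccc1OCCCCCN(C)C` gives 1.61; compound 3 thus stands level with compound 2 and, together with it, at the top of the three, though a number 0.04 log units higher from compound 1 to compound 3 (within the scatter) and a number 0.04 log units higher from compound 1 to compound 2 (within the scatter) leave all three within the scatter of each other. Compound 4 `COc1cc(/C=C/C(=O)Nc2ccccc2)ccc1OCCCCCCN1CCCCC1` differs from compound 3 by (piperidin-1-yl)methyl in place of dimethylamino on a saturated chain carbon, five bonds along the chain from an oxygen on an aromatic ring. Going by the values given here, the closest precedent is no change at the digits printed from compound 2 to compound 3 (within the scatter), the same pair of groups exchanged in the opposite direction, and a number 0.04 log units higher from compound 1 to compound 2 (within the scatter) was likewise flat, so no shift beyond the scatter is expected in this assay; compound 4 is estimated at 1.7, between 1.4 and 2, which means an expected step of a number 0.09 log units higher from compound 3 to compound 4 (within the scatter).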

Compound 4, partition coefficient: 1.77
The estimate for compound 4 lay 0.07 log units below the measured number; the range from low to high includes it.
By their numbers in this assay, from the lowest: compounds 1, 2, 3 and 4 (each within the scatter of the next).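

Replacing dimethylamino with (piperidin-1-yl)methyl, five bonds along the chain from an oxygen on an aromatic ring, brings in a six-membered ring, yet in this assay the step stays small (a number 0.16 log units higher from compound 3 to compound 4 (within the scatter)). The steps that also span a different chain length are no clearer (a number 0.16 log units higher from compound 2 to compound 4 (within the scatter); a number 0.20 log units higher from compound 1 to compound 4 (within the scatter)), so even the largest step in this set stays within the scatter. Nothing shown gives a reason for these small steps. On these data alone, whether a chain ending in a morpholine ring or a carboxylic acid would step beyond the scatter remains open.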